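The compounds below may be only part of what the source reports. "The series", "measured", "known", "first", "only" and "open" are said of these compounds alone.

Measured in a physicochemical assay for lipophilicity; on this read-out lower numbers stand for lower lipophilicity and higher numbers for higher lipophilicity:
- compound 1, `CNC(=O)c1cc(C(=O)N[C@H]2CC[C@H](O)CC2)c([C@@H](C)c2ccc(Cl)cc2)o1`: 3.5
- compound 2, `CNC(=O)c1cc(C(=O)NC2CCOCC2)n([C@@H](C)c2ccccc2)n1`: 3.6
- compound 3, `CNC(=O)c1cc(C(=O)NC2CC2)cn(Cc2cccc3[nH]ccc23)c1=O`: 2.9

Compound 2 carries the highest of the three numbers, but the gap to compound 1 lies within the scatter of this assay, so the two cannot be told apart; only compound 3 sits clearly lower, beyond the scatter. Within the data shown here, no pair of these three differs in a single place, so no measured step is available to lean on.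

Compound 4, `CCCNC(=O)c1cc(C(=O)NC)nn1[C@@H](C)c1ccccc1`, is the next member and has not been measured in this assay. It is compared to compound 2 by a single change: propyl in place of oxan-4-yl on an amide-type nitrogen. The group that leaves is a ring bearing 1 hydrogen-bond acceptor; the group that enters is an open chain of 3 carbon atoms with 0 hydrogen-bond acceptors. With no measured step of this kind in the set, the expectation rests on compound 2 alone, which gives 3.6. A modest rise is expected, of about a number 0.30 log units higher from compound 2 to compound 4 (within the scatter), probably at the edge of the scatter rather than far beyond it. Compound 4 is therefore estimated at 3.9, within 3.4 to 4.4.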

Compound 4, distribution coefficient: 4.4
Beside the measured number, compound 4's estimate is 0.50 log units below it; measured number inside the range.
By their numbers in this assay, from the lowest: compound 3; then compounds 1 and 2 (each within the scatter of the next); then compound 4.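

In this assay, among these compounds, the amide-type nitrogen proves to be a place where a single change moves the number clearly: propyl in place of oxan-4-yl gives a number 0.80 log units higher from compound 2 to compound 4 (beyond the scatter), the first step that can be read from one change. That change alters several things at once, as a six-membered ring gives way to an open chain, the hydrogen-bond acceptor goes and the heavy-atom count falls, so this step cannot be divided among them. No independent measurement bears on the origin of the step.

A cyclohexyl group would keep the ring without its oxygen, and a 2-methoxyethyl chain would keep an oxygen without the ring, so either could help separate these contributions. On these data alone, whether a step of this size carries over to the cores of compound 1 and compound 3 remains open.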